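The compounds below may be only part of what the source reports. "The series", "measured", "known", "first", "only" and "open" are said of these compounds alone.

Compound 3 `CCc1ccccc1-c1cc2c(cn1)ncn2-c1ccc(OC(F)F)cc1` sits second highest of the three numbers recorded in a functional assay on HL-60 cells (Homo sapiens) for activation, read by flow cytometry, with a stated time of 4 days; a higher number here means that more compound is needed for the effect, a lower number that less compound is needed: compound 3 gives 2900 nM. Its nearest neighbour is compound 2 `FC(F)Oc1ccc(-n2cnc3cnc(-c4ccccc4OC(F)(F)F)cc32)cc1`, which in this assay gives 6900 nM, and the furthest is compound 1 `Fc1ccc(-c2cc3c(cn2)ncn3-c2ccc(OC(F)F)cc2)c(Cl)c1`, which in this assay gives 90 nM. The step to compound 4 `Cc1cc(Cl)ccc1-c1cc2c(cn1)ncn2-c1ccc(OC(F)F)cc1` is a change on the shared core: 4-chloro-2-methylphenyl in place of 2-ethylphenyl on an aromatic carbon. Among the compounds with values here, two measured steps bear on it. The first is a 32-fold higher number from compound 1 to compound 3 (1.51 log units; beyond the scatter), which shows that swapping a halogenated phenyl for 2-ethylphenyl at this position carries a large cost. The second is a 2.4-fold lower number from compound 2 to compound 3 (0.38 log units; beyond the scatter), a modest shift within the same position. Compound 4 puts a chlorine back onto the ring and shortens the ethyl to methyl, so it resembles compound 1 more closely than compound 3 does. On that basis a large step in the direction of compound 1 is expected, though not necessarily the whole way, since compound 1 carries a fluorine where compound 4 carries a methyl. Compound 4 is therefore expected to give 220 nM in this assay, in a range from 60 nM to 800 nM, a step of a 13-fold lower number from compound 3 to compound 4 (1.12 log units; beyond the scatter).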

Compound 4, half-maximal effective concentration: 28 nM
The estimate for compound 4 lay 7.9-fold (0.90 log units) above the measured number, and the stated range ends above it.
By their numbers in this assay, from the lowest: compound 4; then compound 1; then compound 3; then compound 2.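

In this assay, within the data shown here, the position is far more tolerant than the earlier compounds suggested: 4-chloro-2-methylphenyl in place of 2-ethylphenyl gives a 100-fold lower number from compound 3 to compound 4 (2.02 log units; beyond the scatter) and so more than recovers the loss seen with 2-ethylphenyl. The same position also gives a 3.2-fold lower number from compound 1 to compound 4 (0.51 log units; beyond the scatter) when 4-chloro-2-methylphenyl replaces 2-chloro-4-fluorophenyl, which shows that among these compounds the best number does not need the 2-chloro-4-fluorophenyl pattern and that a ring with methyl and chlorine can surpass it. A small alkyl group on this ring is therefore compatible with a low number when chlorine is also present, although 2-ethylphenyl alone gives a much higher one, and nothing available explains this difference.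

The step from 2-ethylphenyl to 4-chloro-2-methylphenyl changes the alkyl group and adds chlorine at once, so the compounds shown cannot divide the gain between shortening ethyl to methyl and introducing chlorine. They also leave open how this position would respond to a methoxy group, a nitrile or an amine on the ring, and whether the gain holds when the difluoromethoxy group on the other aryl ring is replaced.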